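Swapping methoxycarbonyl for tert-butyl on the shared core

The compounds below may be only part of what the source reports. "The series", "measured", "known", "first", "only" and "open" are said of these compounds alone.

Compound 2 `COC(=O)c1ccc(N2C(=O)C=CC2OCC(F)(F)F)cc1` carries a methoxycarbonyl group on its aromatic ring. Going by the values given here, in a functional assay on MDA-MB-231 cells (Homo sapiens) for inhibition (a higher number here means a weaker inhibitor, a lower number a stronger inhibitor), compound 2 gives 12100 nM, the highest of the two numbers measured so far, although its only neighbour lies within the scatter of it: compound 1 `CCc1ccc(N2C(=O)C=CC2OCC(F)(F)F)cc1` gives 7840 nM in this assay, and the step of a 1.5-fold higher number from compound 1 to compound 2 (0.19 log units; within the scatter) does not exceed the scatter of repeated measurements.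

Compound 3 `CC(C)(C)c1ccc(N2C(=O)C=CC2OCC(F)(F)F)cc1` differs from compound 2 in one place: tert-butyl in place of methoxycarbonyl on an aromatic carbon. Among the compounds with values here, the single measured step bears on this change only indirectly. It compares ethyl with methoxycarbonyl in the same position, and since ethyl and tert-butyl are both saturated carbon groups without hydrogen-bond acceptors, the ethyl compound 1 with 7840 nM is the closer reference. On that basis the step to compound 3 is expected to be small, at most a modest move toward lower numbers, with a 1.7-fold lower number from compound 2 to compound 3 (0.24 log units; within the scatter) anticipated. Compound 3 is therefore estimated at 7000 nM in this assay, with a range from 3000 nM to 18000 nM.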

Compound 3, half-maximal inhibitory concentration: 1860 nM
Compound 3: middle estimate off by 3.8-fold (0.58 log units), on the high side; measured number outside the range, below it.
By their numbers in this assay, from the lowest: compound 3; then compounds 1 and 2 (each within the scatter of the next).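

In this assay the position para to a large group had so far shown no step beyond the scatter, but it now responds to the group placed there: a 6.5-fold lower number from compound 2 to compound 3 (0.81 log units; beyond the scatter), and a 4.2-fold lower number from compound 1 to compound 3 (0.62 log units; beyond the scatter). Methoxycarbonyl and tert-butyl each count 4 heavy atoms, so the first step occurs with no change in that count, and the second shows that the lower number does not depend on leaving methoxycarbonyl alone, since tert-butyl also stands apart from ethyl, while ethyl and methoxycarbonyl remain within the scatter of each other. No measurement at hand explains why tert-butyl stands apart from the other two groups.

The compounds shown leave open whether the lower number is particular to tert-butyl or extends to other groups at this position, such as isopropyl, cyclohexyl, an amine or a carboxylic acid. They also leave open whether tert-butyl would give a similar step if the rest of the shared core were changed, for instance with a methoxy group in place of the trifluoroethoxy chain.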